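Pyridine-linked bis(hydroxyphenyl) series: topoisomerase 1 inhibition notes

This account rests on a few compounds, and the source may have more. Where it says the series, first, only, none or still open, it means among the compounds named here.

Measured so far in an assay on isolated protein for inhibition of DNA topoisomerase 1 (Homo sapiens), with a stated time of 30 min, tested at 100 uM; on this read-out lower numbers stand for a weaker effect and higher numbers for a stronger effect at the one concentration tested:
compound 1 `Oc1cccc(-c2cc(-c3ccccn3)cc(-c3ccccc3O)n2)c1` gives 35.4%;
compound 2 `Oc1cccc(-c2cc(-c3ccccn3)cc(-c3cccc(O)c3)n2)c1` gives 8.3%;
compound 3 `Oc1cccc(-c2cc(-c3cccnc3)cc(-c3ccccc3O)n2)c1` gives 1.9%.

Two single changes start from compound 1. The first, (3-hydroxyphenyl in place of 2-hydroxyphenyl on an aromatic carbon), gives a number 27.1 percentage points lower from compound 1 to compound 2 (beyond the scatter). The second, (pyridin-3-yl in place of pyridin-2-yl on an aromatic carbon), gives a number 33.5 percentage points lower from compound 1 to compound 3 (beyond the scatter). The values of compound 2 and compound 3 lie within the scatter of each other, so no order between them is read.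

Compound 4 `Oc1cccc(-c2cc(-c3cccnc3)cc(-c3cccc(O)c3)n2)c1` is not yet measured. It differs from compound 3 by 3-hydroxyphenyl in place of 2-hydroxyphenyl on an aromatic carbon. This is the same kind of change as that from compound 1 to compound 2, made on a core that differs by pyridin-3-yl in place of pyridin-2-yl on an aromatic carbon; around the place, the group is meta to a pyridin-3-yl group rather than meta to a pyridin-2-yl group. The earlier step lowered the read-out by a modest amount. Compound 3 already sits near the floor of this read-out, so the room for a further drop is small. For compound 4 in this assay a step of a number 0.9 percentage points lower from compound 3 to compound 4 (within the scatter) is expected, resting on compound 3 at 1.9% and the direction of a number 27.1 percentage points lower from compound 1 to compound 2 (beyond the scatter). Compound 4 is therefore estimated at 1%, expected between 0% and 10%.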

Compound 4, a percentage reported as inhibition, at one concentration (the size of the read-out at that concentration, not a potency): 2.1%
Estimate against measurement, compound 4: 1.1 percentage points below, within the range that was stated.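

In this assay, 3-hydroxyphenyl in place of 2-hydroxyphenyl gives a number 0.2 percentage points higher from compound 3 to compound 4 (within the scatter), so this change does not carry over with the same size from one core to the other: the same change on two cores in this assay, a number 27.1 percentage points lower (beyond the scatter) from compound 1 to compound 2 and a number 0.2 percentage points higher (within the scatter) from compound 3 to compound 4, 27.3 percentage points apart, beyond the scatter of two such steps

The same holds for pyridin-3-yl in place of pyridin-2-yl, which here gives a number 6.2 percentage points lower from compound 2 to compound 4 (within the scatter): the same change on two cores in this assay, a number 33.5 percentage points lower (beyond the scatter) from compound 1 to compound 3 and a number 6.2 percentage points lower (within the scatter) from compound 2 to compound 4, 27.3 percentage points apart, beyond the scatter of two such steps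

Both new steps start from values near the floor of the read-out, so the data show that a step seen on the core of compound 1 cannot be assumed on these weaker cores, but they do not show why, nor how either change would behave on another core with a higher read-out.

The compounds shown leave open whether the read-out of compound 1 survives other groups at these places, such as a methoxy group in place of the hydroxyl or pyridin-4-yl in place of pyridin-2-yl. With one tested concentration, they show for this series only a stronger or weaker effect at that concentration.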